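The compounds below may be only part of what the source reports. "The series", "measured", "known", "first", "only" and "open" are said of these compounds alone.

Measured so far:
Compound 1, `O=C(Nc1ccc(Oc2ccnc3[nH]ccc23)cc1)c1cn(-c2ccc(Br)cc2F)c2ccccc2c1=O`, gives 1330 nM in a functional assay on A549 cells (Homo sapiens) for inhibition, read by MTT assay, with a stated time of 72 h; a higher number here means a weaker inhibitor, a lower number a stronger inhibitor.
Compound 2, `O=C(Nc1ccc(Oc2ccnc3[nH]ccc23)cc1)c1cn(-c2ccc(C(F)(F)F)cc2Cl)c2ccccc2c1=O`, gives 2350 nM in this assay.
Compound 3, `Cn1ccc2c(Oc3ccc(NC(=O)c4cn(-c5ccc(Br)cc5F)c5ccccc5c4=O)cc3F)ccnc21`, gives 1520 nM in this assay.

Compound 1 and compound 2 share one core and differ in a single place: 2-chloro-4-(trifluoromethyl)phenyl in place of 4-bromo-2-fluorophenyl on an aromatic nitrogen. That exchange gave a 1.8-fold higher number from compound 1 to compound 2 (0.25 log units; within the scatter). Compound 3 rests on a different core; the difference between the core of compound 3 and the core of compound 1 is not broken down here. Its value sits close to those of compound 1 and compound 2, and all three lie within the usual scatter of one another, so no ranking among them can be drawn.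

Compound 4, `Cn1ccc2c(Oc3ccc(NC(=O)c4cn(-c5ccc(C(F)(F)F)cc5Cl)c5ccccc5c4=O)cc3F)ccnc21`, has not yet been measured in this assay. It stands to compound 3 exactly as compound 2 stands to compound 1: 2-chloro-4-(trifluoromethyl)phenyl in place of 4-bromo-2-fluorophenyl on an aromatic nitrogen. The surroundings of the exchanged group read the same in both pairs, so this is the same change carried onto the core of compound 3. Within the data shown here, the only guide to its effect is the measured pair, which gave a 1.8-fold higher number from compound 1 to compound 2 (0.25 log units; within the scatter). On that basis compound 4 is expected to show a 1.7-fold higher number from compound 3 to compound 4 (0.23 log units; within the scatter). Since that guiding step itself lay within the scatter, compound 4 may just as well come out level with compound 3. The estimate for compound 4 is 2600 nM, with a range expected from 1300 nM to 5500 nM.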

Compound 4, half-maximal inhibitory concentration: 2050 nM
For compound 4 the middle estimate is 1.3-fold (0.10 log units) above the measured one; low and high end bracket the measured number.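

In this assay, setting 2-chloro-4-(trifluoromethyl)phenyl in place of 4-bromo-2-fluorophenyl on the aromatic nitrogen of the core of compound 3 gave a 1.3-fold higher number from compound 3 to compound 4 (0.13 log units; within the scatter), and this can be set beside the same exchange on the core of compound 1: the same change on two cores in this assay, a 1.8-fold higher number (0.25 log units; within the scatter) from compound 1 to compound 2 and a 1.3-fold higher number (0.13 log units; within the scatter) from compound 3 to compound 4, 1.3-fold (0.12 log units) apart, within the scatter of two such steps. The two pairs therefore agree as far as they can be read: the exchange stays within the scatter on both cores, and the two steps cannot be told apart, so nothing suggests that the core alters its effect. This does not show that the exchange has a real effect on either core, and a change this small gives only a weak test of transfer, since a step that cannot be separated from the scatter says little about how a larger one would carry from one core to another.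

Both groups on the aromatic nitrogen are halogen-bearing phenyl rings, so the compounds shown leave open whether an unsubstituted phenyl, a simple ethyl chain, or a phenyl ring carrying an amine or a carboxylic acid would move the number beyond the scatter. They also leave open how the parts that separate the core of compound 1 from the core of compound 3 each contribute on their own.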